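Swapping a Sulfur Chain for a Basic Amine

This account rests on a few compounds, and the source may have more. Where it says the series, first, only, none or still open, it means among the compounds named here.

Of the compounds shown here, three share a bicyclic core and have been tested in a functional assay on the whole organism with Mus musculus as the target; a higher number here means that more compound is needed for the effect, a lower number that less compound is needed. Compound 1, with structure `Cc1cc(N)c(C)c2c1OC(C)(C)C2`, gives 32.3 mg/kg in this assay. Compound 2, with structure `Cc1c(C)c2c(c(N)c1N)CC(C)(C)O2`, reaches only the limit > 50 mg/kg in this assay, so no number is known for it. Compound 3, with structure `CCCSCC1(C)Cc2c(C)c(N)c(C)c(C)c2O1`, gives 24.6 mg/kg in this assay, the lowest of the two numbers shown, though its gap to compound 1 lies within the usual scatter, so the two cannot be ranked against each other. One of the three results sits at the limit of > 50 mg/kg in this assay, at which 1 of the 3 values shown sits.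

Compound 4, with structure `Cc1c(C)c2c(c(C)c1N)CC(C)(CCN(C)C)O2`, has not yet been measured. It differs from compound 3 in one place: (dimethylamino)methyl in place of propylsulfanyl on a saturated chain carbon bound to a saturated ring carbon. For the measured compounds named here, no pair of measured compounds differs in just one place, so no measured step shows how such a swap shifts this assay. The expectation is therefore a step no larger than the scatter, in either direction, a 1.1-fold higher number from compound 3 to compound 4 (0.06 log units; within the scatter). Compound 4 is accordingly estimated at 28 mg/kg in this assay, within a range from 11 mg/kg to 70 mg/kg.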

Compound 4, dose for 50% inhibition: 19 mg/kg
Beside the measured number, compound 4's estimate is 1.5-fold (0.17 log units) above it; measured number inside the range.
By their numbers in this assay, from the lowest: compounds 4, 3 and 1 (each within the scatter of the next). At a limit, above all of these: compound 2.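

In this assay, for the compounds shown here, replacing propylsulfanyl with (dimethylamino)methyl on a saturated chain carbon bound to a saturated ring carbon gives a 1.3-fold lower number from compound 3 to compound 4 (0.11 log units; within the scatter), which is the first measured step at this place. This shows that, for this pair, the chain can lose its sulfur and gain a nitrogen without the number moving beyond the usual scatter, so the sulfur is not needed to keep the effect in this range. Nothing measured here explains why the number holds across this change.

From the compounds shown here alone, whether the same holds for a carboxylic acid, a primary amine or a longer chain at this place remains open. Also open, going by these compounds, is whether the nitrogen of the 2-(dimethylamino)ethyl chain matters at all, which a plain butyl chain in the same place could help to settle.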